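The compounds below may be only part of what the source reports. "The series", "measured", "known", "first", "only" and "open" are said of these compounds alone.

Working notes on the series. In a functional assay on MGC-803 cells (Homo sapiens) for inhibition, read by MTT assay, with a stated time of 72 h (a higher number here means a weaker inhibitor, a lower number a stronger inhibitor), compound 1 (`FC(F)(F)c1ccc(CSc2nc(N3CCN(c4ncccn4)CC3)cc(C(F)(F)F)n2)cc1`) gives 35200 nM and compound 2 (`Cc1csc(Sc2cc(C(F)(F)F)nc(SCc3ccc(C(F)(F)F)cc3)n2)n1`) gives 21300 nM. These two values lie within the usual scatter of each other, so the numbers set no order between the two compounds. Compound 3 (`FC(F)(F)c1ccc(CSc2nc(Sc3nncs3)cc(C(F)(F)F)n2)cc1`) has not yet been measured in this assay. Its structure differs from that of compound 2 by one change: 1,3,4-thiadiazol-2-yl in place of 4-methyl-1,3-thiazol-2-yl on a sulfur. In words, 1,3,4-thiadiazol-2-yl stands in place of 4-methyl-1,3-thiazol-2-yl on a sulfur. Within the data shown here, no measured pair shows the size of such a change, so no step beyond the scatter is expected in this assay, and neither direction is favoured. The expected change is a 1.2-fold higher number from compound 2 to compound 3 (0.07 log units; within the scatter), which remains within the scatter. The estimated value for compound 3 is 25000 nM, with an expected range of 8000 nM to 60000 nM.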

Compound 3, half-maximal inhibitory concentration: 10900 nM
For compound 3 the middle estimate is 2.3-fold (0.36 log units) above the measured one; the range from low to high includes it.
By their numbers in this assay, from the lowest: compounds 3, 2 and 1 (each within the scatter of the next, the first and the last beyond it).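

Among these compounds, this is the first pair that differs only in the five-membered aromatic ring on the sulfur. In this assay, 1,3,4-thiadiazol-2-yl in place of 4-methyl-1,3-thiazol-2-yl gives a 2.0-fold lower number from compound 2 to compound 3 (0.29 log units; within the scatter), so this change sets no order between the two compounds. The pair therefore shows that this position tolerates the loss of the methyl together with the change in ring hetero atoms without a step beyond the scatter, and no measurement at hand explains the result.

Going by these compounds, the methyl and the ring hetero atoms change together here, so their separate contributions remain open, and a plain 1,3-thiazol-2-yl would separate them. Also open, on these data alone, is whether a phenyl ring or an amine-bearing ring on this sulfur would give a step beyond the scatter.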